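The compounds below may be only part of what the source reports. "The series", "measured", "known", "first", "only" and "open" are said of these compounds alone.

Compound 1 `Cc1cnc(NC(=O)c2cc(Oc3cnc(C(=O)N(C)C)cn3)c3cc(C)oc3c2)cn1`: 176000 nM
Compound 2 `Cc1cnc(NC(=O)c2cc(Oc3cnc(C(=O)N4CCCCC4)cn3)c3cc(C)oc3c2)cn1`: 24000 nM

In a physicochemical assay for solubility, measured as kinetic solubility (on this read-out higher numbers stand for higher solubility and lower numbers for lower solubility), compound 1 is the higher of the two at 176000 nM. Compound 3 `Cc1cc2c(Oc3cnc(C(=O)N(C)C)cn3)cc(C(=O)Nc3cnc(C(F)(F)F)cn3)cc2o1` is not yet measured. It has trifluoromethyl in place of methyl on an aromatic carbon. Going by the values given here, the only measured step is a 7.3-fold lower number from compound 1 to compound 2 (0.87 log units; beyond the scatter). That step is a different change at a different place, so it serves only as a guide to size. A lower number of similar size is expected, and the estimated step is a 3.2-fold lower number from compound 1 to compound 3 (0.51 log units; beyond the scatter). Compound 3 is expected at 55000 nM, within an estimated range of 16000 nM to 150000 nM.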

Compound 3, solubility: 6000 nM
The estimate for compound 3 lay 9.2-fold (0.96 log units) above the measured number; the measured number lies below the stated range.
By their numbers in this assay, from the lowest: compound 3; then compound 2; then compound 1.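

In this assay, trifluoromethyl in place of methyl on the aromatic ring with 2 nitrogen gives a 29-fold lower number from compound 1 to compound 3 (1.47 log units; beyond the scatter). This position therefore moves the read-out too, and by more than the piperidin-1-yl change on the carbonyl carbon, which gave a 7.3-fold lower number from compound 1 to compound 2 (0.87 log units; beyond the scatter). No measured property is at hand to account for the step.

Open, on these data alone, is how a methoxy group, chlorine or an amine at this ring carbon would read. Also open, as far as these compounds go, is whether trifluoromethyl gives a step of similar size alongside piperidin-1-yl.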